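The compounds below may be only part of what the source reports. "The series", "measured", "known", "first", "only" and "open" are said of these compounds alone.

Measured compounds in a functional assay on PLC5 cells (Homo sapiens) for inhibition, read by MTT assay, with a stated time of 24 h; on this read-out lower numbers stand for stronger inhibition and higher numbers for weaker inhibition:
Compound 1 `CNC(=O)c1cc(Oc2cccc(NS(=O)(=O)c3cccc(C(F)(F)F)c3)c2)ccn1` gives 8400 nM.
Compound 2 `Nc1cc(Oc2cccc(NS(=O)(=O)c3cccc(C(F)(F)F)c3)c2)ccc1[N+](=O)[O-]` gives 3900 nM.
Compound 3 `Nc1ccc(Oc2cccc(NCc3cccc(OC(F)(F)F)c3)c2)cc1N` reaches only the limit > 15000 nM, which is a bound of the assay and not a number.

Of the two numbers shown, compound 2 has the lowest, and its nearest neighbour is compound 1. The step between them, a 2.2-fold lower number from compound 1 to compound 2 (0.33 log units; beyond the scatter), came from exchanging the group attached to the ether oxygen. Compound 4 `O=c1[nH]c2ccc(Oc3cccc(NS(=O)(=O)c4cccc(C(F)(F)F)c4)c3)cc2[nH]1` keeps the rest of compound 2 unchanged and differs only at that same oxygen: a group of 10 heavy atoms (7 carbon, 2 nitrogen, 1 oxygen; one five-membered aromatic ring with 2 hetero atoms, one six-membered aromatic ring of carbon only) in place of a group of 10 heavy atoms (6 carbon, 2 nitrogen, 2 oxygen; one six-membered aromatic ring of carbon only), on an oxygen on an aromatic ring. Among the measured compounds shown here, no measured pair exchanges these two particular groups, so no step speaks to the change directly. For the measured compounds named here, the one measured step at this position, a 2.2-fold lower number from compound 1 to compound 2 (0.33 log units; beyond the scatter), was modest. Compound 3, which alters both the group on the oxygen and the linker on the other side, sits at the limit (the limit of > 15000 nM in this assay, at which 1 of the 3 values shown sits), and so gives no number to compare. The outlook is therefore a step of no more than modest size, in no firm direction. The expected value for compound 4 in this assay is 4000 nM, with a range from 1000 nM to 15000 nM. This estimate corresponds to a step of a 1.0-fold higher number from compound 2 to compound 4 (0.01 log units; within the scatter).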

Compound 4, half-maximal inhibitory concentration: 11500 nM
The estimate for compound 4 lay 2.9-fold (0.46 log units) below the measured number, within the range that was stated.
By their numbers in this assay, from the lowest: compound 2; then compounds 1 and 4 (each within the scatter of the next). At a limit, above all of these: compound 3.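

In this assay, the exchange on the oxygen now reaches a group with a second ring, and it gives up what the 3-amino-4-nitrophenyl group had gained: a 2.9-fold higher number from compound 2 to compound 4 (0.47 log units; beyond the scatter). Set against the group on compound 1, the two-ring group makes no difference that can be told from noise: a 1.4-fold higher number from compound 1 to compound 4 (0.14 log units; within the scatter). With the rest of the structure held fixed, the picture at this position is therefore not a gradual trend across three groups but a single group standing apart, with 3-amino-4-nitrophenyl alone giving a lower number, and nothing measured here accounts for that difference.

Which part of the 3-amino-4-nitrophenyl group goes with the lower number stays open, and a plain phenyl ring, or a phenyl ring carrying only the amine or only the nitro group, would separate the two. Also open, from the compounds shown here alone, is whether a quite different group on this oxygen, such as a carboxylic acid or a longer carbon chain, would move the number further than any of the modest steps seen so far.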